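The source may hold more compounds than are shown below. What is called first, only, known or untested is meant among the compounds shown, and "the series" means these compounds.

Measured so far in an assay on isolated protein for inhibition of cathepsin S (Homo sapiens); a lower number here means a stronger inhibitor, a higher number a weaker inhibitor:

- compound 1, `COc1cccc(C(=O)N[C@@H](CCC2CCCCC2)C(=O)NCCN2CCc3cc(F)ccc32)c1`: 2130 nM
- compound 2, `COc1cccc(C(=O)N[C@@H](CCC2CCCCC2)C(=O)N[C@@H](COCc2ccccc2)CN2CCc3cc(F)ccc32)c1`: 23 nM
- compound 3, `COc1cccc(C(=O)N[C@@H](CCC2CCCCC2)C(=O)N[C@@H](CCCN)CN2CCc3cc(F)ccc32)c1`: 76 nM

Compound 3 stands second of the three in this assay, with compound 2 nearest (a 3.3-fold higher number from compound 2 to compound 3 (0.52 log units; beyond the scatter)) and compound 1 furthest (a 28-fold lower number from compound 1 to compound 3 (1.45 log units; beyond the scatter)).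

Compound 4, `CCOC(=O)C[C@@H](CN1CCc2cc(F)ccc21)NC(=O)[C@H](CCC1CCCCC1)NC(=O)c1cccc(OC)c1`, differs from compound 3 in one place: ethoxycarbonyl in place of 2-aminoethyl on a saturated chain carbon, two bonds along the chain from an amide-type nitrogen.

Within the data shown here, two steps bear on this. Any substituent at this chain carbon has given a large drop relative to hydrogen: a 28-fold lower number from compound 1 to compound 3 (1.45 log units; beyond the scatter) and a 93-fold lower number from compound 1 to compound 2 (1.97 log units; beyond the scatter). Between the two substituents tried, the gap is only modest: a 3.3-fold higher number from compound 2 to compound 3 (0.52 log units; beyond the scatter). The entering group is neutral, carries no donor, and has not been tried here, so its exact standing is open; the expectation is a number close to compound 3, with a modest move in either direction, more likely towards compound 2 than towards compound 1.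

For compound 4 in this assay the estimate is 60 nM, range 15 nM to 250 nM, expected step a 1.3-fold lower number from compound 3 to compound 4 (0.10 log units; within the scatter).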

Compound 4, inhibition constant: 16 nM
Estimate against measurement, compound 4: 3.8-fold (0.57 log units) above; the range from low to high includes it.
By their numbers in this assay, from the lowest: compounds 4 and 2 (each within the scatter of the next); then compound 3; then compound 1.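

Ethoxycarbonyl on this saturated chain carbon, two bonds along the chain from an amide-type nitrogen, improves on 2-aminoethyl in this assay (a 4.8-fold lower number from compound 3 to compound 4 (0.68 log units; beyond the scatter)), so an open-chain group with 0 hydrogen-bond donors can do better here than the amine. Ethoxycarbonyl and benzyloxy cannot be separated (a 1.4-fold lower number from compound 2 to compound 4 (0.16 log units; within the scatter)), which shows that a ring in the substituent is not required for a number at this level. Against the unsubstituted chain, the gain is the largest step seen at this carbon so far (a 130-fold lower number from compound 1 to compound 4 (2.12 log units; beyond the scatter)), although it sits within the scatter of the gain given by benzyloxy.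

Nothing available explains these differences. Still open, as far as these compounds go, is whether the free carboxylic acid, a primary amide or a longer ester chain at this carbon would keep the number of compound 4.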